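Methyl for methoxy on the chain carbon: outlook for compound 3

This account rests on a few compounds, and the source may have more. Where it says the series, first, only, none or still open, it means among the compounds named here.

Measured so far:
compound 1 `COCC(C(=O)N1CCN(c2cccc(C(F)(F)F)c2)CC1)N1C(=O)CCC1=O` — 75%
compound 2 `CC(C(=O)N1CCN(c2ccccc2C(F)(F)F)CC1)N1C(=O)CCC1=O` — 75%

Both measured compounds were tested in a functional assay on the whole organism (strain Swiss) with Mus musculus as the target, with a stated time of 1 h, at a dose of 300 mg/kg; a lower number here means a weaker effect, a higher number a stronger effect of the compound at the dose given. In this assay compound 1 gives 75% and compound 2 gives 75%; compound 1 therefore stands level with compound 2 at the digits shown, within the scatter of this kind of measurement. The two differ in more than one place, so nothing beyond the equality of their values can be read from the pair.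

Compound 3 `CCC(C(=O)N1CCN(c2cccc(C(F)(F)F)c2)CC1)N1C(=O)CCC1=O` has not yet been measured. Compared with compound 1 it carries the change (methyl in place of methoxy on a saturated chain carbon, two bonds along the chain from an amide-type nitrogen in a ring and a carbonyl carbon). Both measured compounds sit at the same level despite differing chains and ring substitution patterns, which gives no basis for expecting a large movement from this exchange. The step from compound 1 to compound 3 in this assay is expected to be small, a number 3 percentage points lower from compound 1 to compound 3 (within the scatter), not beyond the scatter in either direction. For compound 3 the expected value in this assay is 72%, with a range from 52% to 90%.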

Compound 3, a percentage reported as activity, at one dose (the size of the read-out at that dose, not a potency): 75%
For compound 3 the middle estimate is 3 percentage points below the measured one; low and high end bracket the measured number.
By their numbers in this assay, from the lowest: compounds 1, 2 and 3 (each within the scatter of the next).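

In this assay, putting methyl in place of methoxy on a saturated chain carbon, two bonds along the chain from an amide-type nitrogen in a ring and a carbonyl carbon, gives no change at the digits printed from compound 1 to compound 3 (within the scatter). Within the data shown here, this is the first comparison that isolates a single place, and it shows that at this position, with the rest of compound 1 held constant, the read-out at the dose given does not depend on keeping the oxygen of the methoxy group or its hydrogen-bond acceptor; the same difference, cut one bond further out, reads methoxymethyl to ethyl. The read-out comes from one dose and is not a potency, and the data on hand offer no explanation for this outcome.

The compounds shown leave open whether a longer chain such as butyl, an amine or a carboxylic acid at this chain carbon would keep the read-out at this level. They also leave open whether methoxy and methyl would still match at a lower dose, where one could give a stronger or weaker effect than the other.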